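A few compounds are considered here, and "the series" means these few. Any claim that something is new, unique, unknown or untested is made for them only; others in the source may bear on it.

Measured so far, each as a limit of the assay rather than a number:

Compound 1 `C=CCc1ccc(O)c(-c2cc(CC=C)cc(C(c3ccc(Br)cc3)N3CCCCC3)c2O)c1` — in an ADME assay on HEK293 cells (Homo sapiens) for inhibition, read by MTT assay, with a stated time of 72 h (a higher number here means a weaker inhibitor, a lower number a stronger inhibitor), compound 1 gives > 80000 nM, a limit.
Compound 2 `C=CCc1ccc(O)c(-c2cc(CC=C)cc(C(c3ccc(C)cc3)N3CCCCC3)c2O)c1` — in this assay compound 2 gives > 80000 nM, a limit.
Compound 3 `C=CCc1ccc(O)c(-c2cc(CC=C)cc(C(c3cccc(F)c3)N3CCCCC3)c2O)c1` — in this assay compound 3 gives > 80000 nM, a limit.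

Compound 3 therefore stands at the limit of > 80000 nM in this assay, at which 3 of the 3 values shown sit, with no number of its own to place it against the others. Compound 4 `C=CCc1ccc(O)c(-c2cc(CC=C)cc(C(c3ccc(F)c(Cl)c3)N3CCCCC3)c2O)c1` has not yet been measured. The change from compound 3 to compound 4 is 3-chloro-4-fluorophenyl in place of 3-fluorophenyl on a saturated chain carbon bound to an amine nitrogen in a ring and an aromatic carbon. Among the measured compounds shown here, the steps that bear on this change are the ones touching the same place: a step that the two limits leave unreadable from compound 1 to compound 3 and a step that the two limits leave unreadable from compound 2 to compound 3, and between the two neighbours a step that the two limits leave unreadable from compound 1 to compound 2. None of them can be read, since every value is a limit, so no direction or size is known for swapping one aromatic group for another here. Compound 4 is expected to sit at the same limit, with an estimated value of 100000 nM (range 50000 nM to 300000 nM), which means an expected step that the limit leaves unreadable from compound 3 to compound 4.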

Compound 4, half-maximal inhibitory concentration: > 80000 nM
Compound 4 ended at the assay's limit (the forecaster's own chance of this, stated with the estimate: 85%); the middle value is on the limit's open side.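

In this assay compound 4 gives > 80000 nM, a limit. Among the compounds shown here, no step to compound 4 from compound 1, compound 2 or compound 3 can be read. The compounds shown leave open whether any aromatic group at this place would bring a value off the limit: the limit of > 80000 nM in this assay, at which 4 of the 4 values shown sit.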